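A few compounds are considered here, and "the series" means these few. Any claim that something is new, unique, unknown or untested is made for them only; others in the source may bear on it.

Compound 1 `Nc1cc(Oc2ccc(NC(=O)Nc3cccc(C(F)(F)F)c3)cc2)ncn1` — 25 nM
Compound 2 `CC(C)(O)CNc1cc(Oc2ccc(NC(=O)Nc3cccc(C(F)(F)F)c3)cc2)ncn1` — 40 nM
Compound 3 `O=C(Nc1ccc(Oc2cc(NCCO)ncn2)cc1)Nc1cccc(C(F)(F)F)c1` — 32 nM

All three measured compounds share one core and differ only in what sits on the nitrogen on the aromatic ring. In an assay on isolated protein for inhibition of serine/threonine-protein kinase TNNI3K (Homo sapiens) (a lower number here means a stronger inhibitor, a higher number a weaker inhibitor), compound 3 gives 32 nM, the second highest of the three numbers; its nearest neighbour is compound 2 and its furthest is compound 1, both within the scatter a 1.3-fold lower number from compound 2 to compound 3 (0.10 log units; within the scatter) a 1.3-fold higher number from compound 1 to compound 3 (0.11 log units; within the scatter).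

Compound 4 `CC(=O)Nc1cc(Oc2ccc(NC(=O)Nc3cccc(C(F)(F)F)c3)cc2)ncn1` is not yet measured. It differs from compound 3 by acetyl in place of 2-hydroxyethyl on a nitrogen on an aromatic ring. Among the measured compounds shown here, the steps that bear on this place are those from compound 1, where the nitrogen carries hydrogen, to compound 2 a 1.6-fold higher number from compound 1 to compound 2 (0.20 log units; within the scatter) and to compound 3 a 1.3-fold higher number from compound 1 to compound 3 (0.11 log units; within the scatter): neither left the scatter, so this position has so far accepted hydrogen or a hydroxy-bearing chain without a change in the number. For the measured compounds named here, the acetyl group is the first substituent here without a hydrogen-bond donor on the chain, so the account gives less guidance; no measured step covers it. Compound 4 is therefore expected to stay near compound 3, with the step of a 1.4-fold higher number from compound 3 to compound 4 (0.15 log units; within the scatter) expected to lie within or only slightly beyond the scatter. The estimate for compound 4 is 45 nM, in the range 15 nM to 150 nM.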

Compound 4, half-maximal inhibitory concentration: 20 nM
Beside the measured number, compound 4's estimate is 2.3-fold (0.35 log units) above it, and the stated range covers the measured number.
By their numbers in this assay, from the lowest: compounds 4, 1, 3 and 2 (each within the scatter of the next).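

In this assay, acetyl on the nitrogen on the aromatic ring stays within the scatter of all three earlier compounds (a 1.6-fold lower number from compound 3 to compound 4 (0.20 log units; within the scatter); a 2.0-fold lower number from compound 2 to compound 4 (0.30 log units; within the scatter); a 1.3-fold lower number from compound 1 to compound 4 (0.10 log units; within the scatter)). Unlike the 2-hydroxyethyl it replaces, acetyl carries no hydrogen-bond donor, so a donor on the chain is not needed to keep the number in this range, something the hydrogen and the two hydroxy-bearing chains could not show. Across hydrogen, 2-hydroxyethyl, 2-hydroxy-2-methylpropyl and acetyl, no step at this place has left the scatter.

No measurement shown explains why the number holds across these groups. On these data alone, it remains open whether a dimethylamino-bearing chain, a carboxylic acid, a longer acyl chain or a benzoyl group on this nitrogen would stay within the same range.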